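A few compounds are considered here, and "the series" means these few. Any claim that something is new, unique, unknown or untested is made for them only; others in the source may bear on it.

Within the data shown here, in a functional assay on HepG2 cells (Homo sapiens) for cytotoxicity, read by MTT assay, with a stated time of 48 h (on this read-out lower numbers stand for stronger inhibition and higher numbers for weaker inhibition), compound 1 `O=C1/C(=C\c2ccccc2)S/C(=N/c2ccccc2)N1Cc1ccncc1` gives 25200 nM, the middle of the three numbers measured so far. Compound 2 `O=C1/C(=C\c2ccc(O)cc2)S/C(=N/c2ccccc2)N1Cc1ccncc1` lies lower at 11800 nM, and compound 3 `CN(C)c1ccc(/C=C2/S/C(=N/c3ccccc3)N(Cc3ccncc3)C2=O)cc1` lies higher at 52600 nM. Compound 4 `CC(C)c1ccc(/C=C2/S/C(=N/c3ccccc3)N(Cc3ccncc3)C2=O)cc1` has not yet been measured. It keeps the core of compound 1 but has isopropyl in place of hydrogen on an aromatic carbon, para to a large group: isopropyl in place of hydrogen on an aromatic carbon.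

Two measured steps also replace hydrogen on an aromatic carbon. Hydroxy gives a 2.1-fold lower number from compound 1 to compound 2 (0.33 log units; beyond the scatter), while dimethylamino gives a 2.1-fold higher number from compound 1 to compound 3 (0.32 log units; beyond the scatter). Both steps are modest, but they run in opposite directions, and swapping one group for the other gives a 4.5-fold higher number from compound 2 to compound 3 (0.65 log units; beyond the scatter). A new group could therefore move the number either way. The nearer match to isopropyl is the branched dimethylamino group of compound 3 at 52600 nM, so a small move towards higher numbers, meaning weaker inhibition, is expected in this assay. It may be no larger than the scatter, and three compounds are only a thin guide. The expected change is a 1.4-fold higher number from compound 1 to compound 4 (0.14 log units; within the scatter). Compound 4 is estimated at 35000 nM, with an expected range from 14000 nM to 80000 nM.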

Compound 4, half-maximal inhibitory concentration: 32300 nM
Estimate against measurement, compound 4: 1.1-fold (0.03 log units) above, within the range that was stated.
By their numbers in this assay, from the lowest: compound 2; then compounds 1, 4 and 3 (each within the scatter of the next, the first and the last beyond it).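

In this assay, isopropyl on this carbon ring position gives a 1.3-fold higher number from compound 1 to compound 4 (0.11 log units; within the scatter), so unlike hydroxy and dimethylamino, this group cannot be told apart from plain hydrogen. Isopropyl also cannot be separated from dimethylamino, with a 1.6-fold lower number from compound 3 to compound 4 (0.21 log units; within the scatter), even though compound 1 and compound 3 are printed as lying beyond the scatter of each other, so compound 4 sits in the overlap between those two and does not add a clear new level. Hydroxy remains apart, with a 2.7-fold higher number from compound 2 to compound 4 (0.44 log units; beyond the scatter), and compound 2 is the only one of the four whose number is beyond the scatter of all the others, although no measured information here explains why these groups differ.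

From the compounds shown here alone, whether that separation belongs to hydroxy alone stays open, and a methoxy group, an amine or a carboxylic acid at the same position would test it. A longer chain or a bulkier tert-butyl group would show whether the number stays level beyond isopropyl, and the four compounds shown vary only this one position of the shared core.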